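The compounds below may be only part of what the source reports. "The series", "measured", "known", "first", "only" and "open" are said of these compounds alone.

Compound 1 `CCC1=C(O)c2c(oc(-c3ccccc3C)cc2=O)C(CC)(CC)C1=O`: 40.9 uM
Compound 2 `CCC1=C(O)c2c(oc(-c3ccc(OC)cc3C)cc2=O)C(CC)(CC)C1=O`: 20.9 uM
Compound 3 `CCC1=C(O)c2c(oc(-c3ccc(OC)c(Cl)c3)cc2=O)C(CC)(CC)C1=O`: 24.9 uM

These values come from a functional assay on KB cells (Homo sapiens) for antiproliferative activity, read by sulforhodamine B assay, with a stated time of 3 days; a higher number here means that more compound is needed for the effect, a lower number that less compound is needed. The three compounds share one core and differ only in the aromatic group attached to it. Compound 3 gives 24.9 uM and cannot be separated from the other two compounds, with a 1.2-fold higher number from compound 2 to compound 3 (0.08 log units; within the scatter) and a 1.6-fold lower number from compound 1 to compound 3 (0.22 log units; within the scatter).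

The next compound, compound 4 `CCC1=C(O)c2c(oc(-c3ccc(O)c(C)c3C)cc2=O)C(CC)(CC)C1=O`, keeps the shared core but changes that group again: 4-hydroxy-2,3-dimethylphenyl in place of 3-chloro-4-methoxyphenyl on an aromatic carbon. In words, this places 4-hydroxy-2,3-dimethylphenyl in place of 3-chloro-4-methoxyphenyl, on the aromatic carbon next to the ring oxygen.

The two steps just given bear directly on this exchange, as both alter the same group. A third, a 2.0-fold lower number from compound 1 to compound 2 (0.29 log units; within the scatter), also alters it and also stays within the scatter, so across these three compounds no change to this group has yet moved the number beyond the scatter. For the measured compounds named here, no measured compound carries the 4-hydroxy-2,3-dimethylphenyl group, however, so this expectation remains uncertain, and the data favour no direction.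

The expected change is a 1.1-fold lower number from compound 3 to compound 4 (0.05 log units; within the scatter), which would not be beyond the scatter. For compound 4 the estimated value in this assay is 22 uM, with an expected range from 9 uM to 50 uM.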

Compound 4, concentration for half-maximal effect: 6.5 uM
Beside the measured number, compound 4's estimate is 3.4-fold (0.53 log units) above it, outside the stated range (below it).
By their numbers in this assay, from the lowest: compound 4; then compounds 2, 3 and 1 (each within the scatter of the next).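

In this assay, for the compounds shown here, the steps to compound 4 are the first at this aromatic carbon next to the ring oxygen to pass the scatter, with a 3.8-fold lower number from compound 3 to compound 4 (0.58 log units; beyond the scatter) and a 3.2-fold lower number from compound 2 to compound 4 (0.51 log units; beyond the scatter) and also a 6.3-fold lower number from compound 1 to compound 4 (0.80 log units; beyond the scatter), all modest in size. The number at this position can therefore be moved by the choice of aromatic group, which the three earlier compounds, all within the scatter of each other, did not show. Compound 4 is also the only compound shown with a hydroxy group on that ring, but nothing measured here explains why the number falls.

The compounds shown leave open whether the hydroxy group, the second methyl group or the two together go with the lower number, and a group carrying only one of these changes would separate them. From the compounds shown here alone, how an amine or a carboxylic acid in place of that hydroxy group would read in this assay also remains open, as does whether the lower number would hold in other cell lines.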